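Series notes: the step from compound 3 to compound 4

This account rests on a few compounds, and the source may have more. Where it says the series, first, only, none or still open, it means among the compounds named here.

In a functional assay on MCF7 cells (Homo sapiens) for cytotoxicity, read by MTT assay, with a stated time of 48 h (on this read-out higher numbers stand for weaker inhibition and lower numbers for stronger inhibition), compound 3 `Cc1ccc(/C=N/NC(=O)CSc2nnc(-c3ccncc3)o2)cc1` gives 14700 nM, the second highest of the three numbers. Compound 2 `O=C(CSc1nnc(-c2ccncc2)o1)N/N=C/c1ccc([N+](=O)[O-])cc1` gives 31800 nM, and compound 1 `NNC(=O)CSc1nnc(-c2ccncc2)o1` gives 3260 nM. Among the measured compounds shown here, the only single-point step measured is a 2.2-fold lower number from compound 2 to compound 3 (0.34 log units; beyond the scatter). Compound 4 `O=C(CSc1nnc(-c2ccncc2)o1)N/N=C/c1cc(Cl)ccc1O` differs from compound 3 by 5-chloro-2-hydroxyphenyl in place of 4-methylphenyl on a carbon with a double bond to nitrogen. For the measured compounds named here, that step from compound 2 to compound 3 concerns the same ring and was modest; no measured step brings in a 5-chloro-2-hydroxyphenyl group, so a step of similar or smaller size is expected, direction uncertain. For compound 4 the number is estimated at 12000 nM, within 4000 nM to 40000 nM, the expected step being a 1.2-fold lower number from compound 3 to compound 4 (0.09 log units; within the scatter).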

Compound 4, half-maximal inhibitory concentration: 5830 nM
Estimate against measurement, compound 4: 2.1-fold (0.31 log units) above; the range from low to high includes it.
By their numbers in this assay, from the lowest: compounds 1 and 4 (each within the scatter of the next); then compound 3; then compound 2.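

In this assay, this position responds to more than the swap of nitro for methyl on the same ring: there is a 2.5-fold lower number from compound 3 to compound 4 (0.40 log units; beyond the scatter), and a 5.5-fold lower number from compound 2 to compound 4 (0.74 log units; beyond the scatter). Unlike 4-methylphenyl, the entering 5-chloro-2-hydroxyphenyl group carries chlorine and a hydrogen-bond donor and acceptor, so this place tolerates a group with two ring substituents. Nothing available explains these steps.

Open, as far as these compounds go, is whether the chlorine or the hydroxyl alone carries the step. Also open, from the compounds shown here alone, is how an amine or a carboxylic acid on that ring would read.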